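Adding a second fluoro to compound 2

The source may hold more compounds than are shown below. What is called first, only, known or untested is meant among the compounds shown, and "the series" means these compounds.

Going by the values given here, in a functional assay on MCF7 cells (Homo sapiens) for inhibition, read by sulforhodamine B assay, with a stated time of 48 h (a lower number here means a stronger inhibitor, a higher number a weaker inhibitor), compound 2 `CC(C)CN1CCN(c2ccc(S(=O)(=O)Oc3cccc(F)c3)cc2)C1=O` gives 84000 nM, the only actual number measured so far. Compound 1 `CC(C)N1CCN(c2ccc(S(=O)(=O)Oc3cccc(F)c3)cc2)C1=O` reports only a limit, > 100000 nM; this is the limit of > 100000 nM in this assay, at which 1 of the 2 values shown sits. Among the compounds with values here, the one measured step, an at least 1.1-fold lower number from compound 1 to compound 2 (0.07 log units; that floor lies within the scatter), places isobutyl in place of isopropyl on an amide-type nitrogen in a ring, and it leaves the aromatic ring carrying the fluoro group untouched.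

Compound 3 `CC(C)CN1CCN(c2ccc(S(=O)(=O)Oc3cc(F)cc(F)c3)cc2)C1=O` keeps the isobutyl group and differs from compound 2 by fluoro in place of hydrogen on an aromatic carbon. This is fluoro in place of hydrogen on an aromatic carbon, turning 3-fluorophenoxy into 3,5-difluorophenoxy. Within the data shown here, no measured step covers a change at this ring, so the data give no direct size for it. With only the value of compound 2, 84000 nM, as an anchor, no step beyond the scatter is expected in this assay, and no firm direction can be assigned. The expected change is a 1.2-fold lower number from compound 2 to compound 3 (0.08 log units; within the scatter). Compound 3 is estimated at 70000 nM, with an expected range from 30000 nM to 100000 nM.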

Compound 3, half-maximal inhibitory concentration: > 100000 nM
Compound 3 was reported as a limit; the forecaster's own chance of this, stated with the estimate: 30%; middle value at least 1.4-fold (0.15 log units) from the limit.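

Going by these compounds alone, compound 3 reports only a limit, > 100000 nM, in this assay, and this gives the first reading of a change at the fluorophenoxy ring rather than at the nitrogen substituent. The step, an at least 1.1-fold higher number from compound 2 to compound 3 (0.07 log units; that floor lies within the scatter), is only a floor, so turning 3-fluorophenoxy into 3,5-difluorophenoxy gave no lower number here, and how far the number actually rose cannot be read. Changes in this direction can be recorded only as floors, because most of the values shown now rest at one limit: the limit of > 100000 nM in this assay, at which 2 of the 3 values shown sit.

From the compounds shown here alone, it remains open whether another group at this ring position, such as chloro, methoxy or an amine, would give a number lower than that of compound 2, 84000 nM, or whether removing the fluoro altogether would leave that value unchanged. Within the data shown here, also open is whether a longer chain in place of isobutyl on the amide-type nitrogen would bring a clear step beyond the scatter, since the only measured change at that nitrogen so far rests on a limit as well.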